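Furan-2-yl to thiophen-3-yl: an expected small step

The source may report more compounds than this note shows. Statements on the series, on what has been measured and on what is new or still open speak of the compounds shown alone.

In a functional assay on K562 cells (Homo sapiens) for inhibition, with a stated time of 72 h (on this read-out higher numbers stand for weaker inhibition and lower numbers for stronger inhibition), compound 1 `NC1CCC(Nc2nc(NCc3ccc(-c4ccccc4)cc3)c3ncn(C4CCCC4)c3n2)CC1` gives 530 nM, compound 2 `NC1CCC(Nc2nc(NCc3ccc(-c4cccc(F)c4)cc3)c3ncn(C4CCCC4)c3n2)CC1` gives 290 nM and compound 3 `NC1CCC(Nc2nc(NCc3ccc(-c4ccco4)cc3)c3ncn(C4CCCC4)c3n2)CC1` gives 96 nM, the lowest of the three numbers. Compound 4 `NC1CCC(Nc2nc(NCc3ccc(-c4ccsc4)cc3)c3ncn(C4CCCC4)c3n2)CC1` carries thiophen-3-yl in place of furan-2-yl on an aromatic carbon, para to a large group: thiophen-3-yl in place of furan-2-yl on an aromatic carbon. Among the compounds with values here, no measured step covers this exchange directly. Putting furan-2-yl in place of phenyl gave a 5.5-fold lower number from compound 1 to compound 3 (0.74 log units; beyond the scatter), and putting it in place of 3-fluorophenyl gave a 3.0-fold lower number from compound 2 to compound 3 (0.48 log units; beyond the scatter). Fluoro in place of hydrogen gave a 1.8-fold lower number from compound 1 to compound 2 (0.26 log units; within the scatter). Here, however, one five-membered aromatic ring with one hetero atom replaces another, so no large change is expected in this assay. The expected step is small and upward, within the scatter: a 1.4-fold higher number from compound 3 to compound 4 (0.13 log units; within the scatter). For compound 4 the estimated value is 130 nM, with an expected range of 60 nM to 300 nM.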

Compound 4, half-maximal inhibitory concentration: 150 nM
Estimate against measurement, compound 4: 1.2-fold (0.06 log units) below; measured number inside the range.
By their numbers in this assay, from the lowest: compounds 3, 4, 2 and 1 (each within the scatter of the next, the first and the last beyond it).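

In this assay, thiophen-3-yl takes the place of furan-2-yl with a step inside the scatter (a 1.6-fold higher number from compound 3 to compound 4 (0.19 log units; within the scatter)), so this position accepts a second five-membered aromatic ring with one hetero atom. Like furan-2-yl, thiophen-3-yl lies beyond the scatter from phenyl (a 3.5-fold lower number from compound 1 to compound 4 (0.55 log units; beyond the scatter)), but unlike furan-2-yl it stays within the scatter of 3-fluorophenyl (a 1.9-fold lower number from compound 2 to compound 4 (0.29 log units; within the scatter)). Nothing measured here accounts for these steps. The compounds shown leave open how thiophen-2-yl or furan-3-yl would read at this position, and whether a ring containing nitrogen, such as pyridine or pyrazole, would follow the same course.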